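Aryl triazole ester series: methoxy to fluoro swap

The source may report more compounds than this note shows. Statements on the series, on what has been measured and on what is new or still open speak of the compounds shown alone.

Compound 1 `C#CCOC(=O)/C(C)=C/CC/C(C)=C/CC/C(C)=C/CC[C@@H]1[C@@]2(C)CCC(=O)C(C)(C)[C@H]2CC[C@@]1(C)O` is the parent ester; in a functional assay on A549 cells (Homo sapiens) for antiproliferative activity, read by MTT assay, with a stated time of 48 h (on this read-out higher numbers stand for weaker inhibition and lower numbers for stronger inhibition), compound 1 gives 45100 nM. Compound 2 `C/C(=C\CC/C(C)=C/CC[C@@H]1[C@@]2(C)CCC(=O)C(C)(C)[C@H]2CC[C@@]1(C)O)CC/C=C(\C)C(=O)OCc1cn(-c2cccc(Cl)c2)nn1` gives 147000 nM in this assay, the step of a 3.3-fold higher number from compound 1 to compound 2 (0.51 log units; beyond the scatter). Compound 3 `COc1cccc(-n2cc(COC(=O)/C(C)=C/CC/C(C)=C/CC/C(C)=C/CC[C@@H]3[C@@]4(C)CCC(=O)C(C)(C)[C@H]4CC[C@@]3(C)O)nn2)c1` reaches only the limit of this assay, reported as > 150000 nM. That limit is the one noted as the limit of > 150000 nM in this assay, at which 1 of the 3 values shown sits, so compound 3 stands at the weak end of the three numbers shown, with the step of an at least 1.0-fold higher number from compound 2 to compound 3 (0.00 log units; that floor lies within the scatter) giving no sign of a difference from compound 2 beyond the scatter.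

Compound 4 `C/C(=C\CC/C(C)=C/CC[C@@H]1[C@@]2(C)CCC(=O)C(C)(C)[C@H]2CC[C@@]1(C)O)CC/C=C(\C)C(=O)OCc1cn(-c2cccc(F)c2)nn1` differs from compound 3 by fluoro in place of methoxy on an aromatic carbon. The step that bears on it is the chloro-to-methoxy exchange on the same aromatic carbon, which sat at the floor within the scatter; the change from ethynyl to the aryl triazole was modest. A halogen is thus returned to the position chloro held in compound 2, and no step beyond the scatter is expected, a number no higher from compound 3 to compound 4 (the limit leaves the size open). Compound 4 is estimated at 150000 nM, within 70000 nM to 320000 nM, and may again be reported only as a limit.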

Compound 4, half-maximal inhibitory concentration: 124000 nM
Estimate against measurement, compound 4: 1.2-fold (0.08 log units) above; measured number inside the range.
By their numbers in this assay, from the lowest: compound 1; then compounds 4 and 2 (each within the scatter of the next). At a limit, above all of these: compound 3.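

At this aromatic carbon, fluoro and chloro cannot be told apart in this assay: the step is a 1.2-fold lower number from compound 2 to compound 4 (0.07 log units; within the scatter). The drop from the parent ester is seen again with a second halogen, with a 2.7-fold higher number from compound 1 to compound 4 (0.44 log units; beyond the scatter), so both halogen-bearing aryl triazole esters give higher numbers than the ethynyl parent. The step from the methoxy ester is an at least 1.2-fold lower number from compound 3 to compound 4 (0.08 log units; that floor lies within the scatter). Its size is only a floor, because compound 3 has only a limit, not a number: the limit of > 150000 nM in this assay, at which 1 of the 4 values shown sits.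

On these data alone, what an amine or a carboxylic acid on this aromatic carbon would give remains open, as does the effect of an unsubstituted phenyl. Also open is whether any aryl triazole ester can reach the number of compound 1, since all those shown carry their group in the same place on the ring.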